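The source may report more compounds than this note shows. Statements on the series, on what has been measured and on what is new or still open speak of the compounds shown alone.

The measured compounds, with their numbers in a functional assay on WM 266-4 cells (Homo sapiens) for antiproliferative activity, read by MTT assay, with a stated time of 24 h; on this read-out higher numbers stand for weaker inhibition of growth and lower numbers for stronger inhibition of growth:

compound 1, `COc1ccc(C2=NN(C(=O)c3cncc(Br)c3)C(c3ccc(OC)cc3)C2)cc1`: 7560 nM
compound 2, `COc1ccc(C2=NN(C(=O)c3cccnc3Cl)C(c3ccc(OC)cc3)C2)cc1`: 4350 nM
compound 3, `COc1ccc(C2=NN(C(=O)c3ccc(C)nc3)C(c3ccc(OC)cc3)C2)cc1`: 4930 nM

Compound 3 sits in the middle of the three numbers, though none of the three is separated from another beyond the scatter: the step of a 1.5-fold lower number from compound 1 to compound 3 (0.19 log units; within the scatter) and the step of a 1.1-fold higher number from compound 2 to compound 3 (0.05 log units; within the scatter) are both small, as is a 1.7-fold lower number from compound 1 to compound 2 (0.24 log units; within the scatter). All three measured steps exchange the pyridinyl group on the carbonyl carbon and leave the rest of the shared core untouched.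

Compound 4, `COc1ccc(C2=NN(C(=O)c3ccc(C)nc3)C(c3ccc(OCc4ccccc4)cc3)C2)cc1`, differs from compound 3 elsewhere: phenyl in place of hydrogen on a saturated chain carbon bound to an oxygen on an aromatic ring, that is, methoxy to benzyloxy on one of the two aryl groups of the core. Going by the values given here, no measured step touches this part of the molecule, so nothing in the data speaks for a step in this assay in either direction. Among the compounds with values here, the measured steps show only that this series so far moves little. Compound 4 is therefore expected to show a step of a 1.0-fold higher number from compound 3 to compound 4 (0.01 log units; within the scatter), within the scatter, giving an estimate of 5000 nM with a range from 1800 nM to 14000 nM.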

Compound 4, concentration for 50% growth inhibition: 7950 nM
Beside the measured number, compound 4's estimate is 1.6-fold (0.20 log units) below it; the range from low to high includes it.
By their numbers in this assay, from the lowest: compounds 2, 3, 1 and 4 (each within the scatter of the next).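

In this assay, the change from methoxy to benzyloxy on one of the two aryl groups gives a 1.6-fold higher number from compound 3 to compound 4 (0.21 log units; within the scatter), so the first change away from the pyridinyl group on the carbonyl carbon also stays within the scatter. Going by these compounds alone, the added phenyl, on a saturated chain carbon bound to an oxygen on an aromatic ring, therefore produces no step that can be told apart from repeat measurement in this assay. No measurement at hand bears on why this step is as small as it is.

The compounds shown leave open whether a longer chain between the oxygen and the phenyl, or an amine or a carboxylic acid on that phenyl, would move the number beyond the scatter. As far as these compounds go, it also remains open whether benzyloxy would give a similar step alongside the 2-chloropyridin-3-yl or 5-bromopyridin-3-yl group.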